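The compounds below may be only part of what the source reports. "The series", "measured", "known", "first", "only" and "open" are said of these compounds alone.

In a functional assay on DU-145 cells (Homo sapiens) for inhibition, read by trypan blue exclusion, with a stated time of 96 h (a lower number here means a stronger inhibitor of growth, a higher number a weaker inhibitor of growth), compound 1 `COc1ccccc1/C=C(\C(=O)c1ccc(Cl)cc1)S(=O)(=O)Cc1ccc(C)cc1` gives 10000 nM. Compound 2 `Cc1ccc(CS(=O)(=O)/C(=C/c2ccccc2Br)C(=O)c2ccc(Cl)cc2)cc1` gives 25000 nM, the higher of the two numbers, which makes it the weaker inhibitor of growth of this pair. Compound 3 `Cc1ccc(CS(=O)(=O)/C(=C/c2ccc(C)s2)C(=O)c2ccc(Cl)cc2)cc1` has not yet been measured. It differs from compound 2 at one place, on a double-bonded chain carbon bound to a double-bonded chain carbon: 5-methylthiophen-2-yl in place of 2-bromophenyl on a double-bonded chain carbon bound to a double-bonded chain carbon. Going by the values given here, only one measured step bears on this change, and it is modest: a 2.5-fold higher number from compound 1 to compound 2 (0.40 log units; beyond the scatter). That step swapped bromo for methoxy on an aromatic carbon, whereas here the whole 2-bromophenyl leaves, so it is only a loose guide. A step of similar modest size is therefore expected in this assay, more likely toward a lower number than a higher one, but the data cannot settle the direction. The estimated step is a 2.1-fold lower number from compound 2 to compound 3 (0.32 log units; beyond the scatter). Compound 3 is expected at about 12000 nM, with an estimated range of 4000 nM to 35000 nM.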

Compound 3, concentration for 50% growth inhibition: 25000 nM
Compound 3: the middle estimate sits 2.1-fold (0.32 log units) below what was measured, and the stated range covers the measured number.
By their numbers in this assay, from the lowest: compound 1; then compounds 2 and 3 (each within the scatter of the next).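

At this place on the double-bonded chain carbon, a five-membered sulfur ring can stand in for a six-membered carbon ring, since no change at the digits printed from compound 2 to compound 3 (within the scatter) in this assay. The earlier compounds shown here varied only a group on the ring, whereas this change replaces the whole ring and still leaves the number where it was. The other comparison gives a 2.5-fold higher number from compound 1 to compound 3 (0.40 log units; beyond the scatter), so among these three compounds, 2-methoxyphenyl is the only group at this place that gives the lower number, and no measurement here explains why.

Going by these compounds, whether a pyridine ring, or an amine or a carboxylic acid carried on the ring at this place, would move the number in either direction remains open. Equally open, on these data alone, is how changes elsewhere on the shared core would affect growth inhibition.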